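The source may report more compounds than this note shows. Statements on the series, on what has been measured and on what is new or still open speak of the compounds shown alone.

Working notes on the series.

Going by the values given here, compound 1 `COc1ccc2c(c1)C(CCCN1CCN(c3cccc(C(F)(F)F)c3)CC1)CCC2` stands highest of the two numbers so far in an assay on isolated protein for binding affinity to Adrenergic receptor alpha-1 (Rattus norvegicus), read by radioligand binding; on this read-out higher numbers stand for weaker inhibition and lower numbers for stronger inhibition: compound 1 gives 2930 nM. Compound 2 `COc1ccc2c(c1)C(CCCN1CCN(c3ccccc3OC)CC1)=CCC2` gives 24.5 nM in this assay, a far lower number; compound 2 differs from compound 1 in more than one place, so the two values show only that the series spans a wide range, not which change carries it.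

Compound 3 `COc1ccc2c(c1)C(CCCN1CCN(c3ccccn3)CC1)CCC2` is not yet measured. It differs from compound 1 in one place: pyridin-2-yl in place of 3-(trifluoromethyl)phenyl on an amine nitrogen in a ring. Among the compounds with values here, no measured pair in the set isolates this change, so the size of the step rests on expectation alone. The expected step from compound 1 to compound 3 is a 9.8-fold lower number from compound 1 to compound 3 (0.99 log units; beyond the scatter), toward a lower number, beyond the scatter, on the grounds that compound 1 with 2930 nM sits at the weak end of the range shown. For compound 3 the estimate in this assay is 300 nM, with a range from 60 nM to 1500 nM.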

Compound 3, half-maximal inhibitory concentration: 261 nM
Compound 3: middle estimate off by 1.1-fold (0.06 log units), on the high side; the measured number falls inside the stated range.
By their numbers in this assay, from the lowest: compound 2; then compound 3; then compound 1.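

Going by these compounds alone, this is the first step that isolates a single place: with the rest of the structure unchanged, pyridin-2-yl in place of 3-(trifluoromethyl)phenyl on the amine nitrogen in the ring gives, in this assay, an 11-fold lower number from compound 1 to compound 3 (1.05 log units; beyond the scatter). The group on this nitrogen is therefore enough on its own to shift the number by a large margin beyond the scatter, which the earlier pair, differing in more than one place, could not show. The change bundles several differences, as the entering group has fewer heavy atoms, no fluorine and a ring nitrogen that counts as a hydrogen-bond acceptor, and no measurement at hand bears on which of these matters.

A plain phenyl or a pyrimidin-2-yl on the same nitrogen would help separate the loss of the trifluoromethyl group from the gain of the ring nitrogen, and the compounds shown do not make that separation. On these data alone, the step to compound 2 still cannot be read, so the shares of its 2-methoxyphenyl group and of its other difference from compound 1 remain open.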